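The source may report more compounds than this note shows. Statements on the series, on what has been measured and on what is new or still open speak of the compounds shown alone.

In a functional assay on A549 cells (Homo sapiens) for cytotoxicity, read by MTT assay, with a stated time of 72 h (on this read-out lower numbers stand for stronger inhibition and higher numbers for weaker inhibition), the measured compounds give:
Compound 1 (`CCOC(=O)c1sc2ccccc2c1Nc1cc(OC)c(OC)c(OC)c1`): 8530 nM
Compound 2 (`CCOC(=O)c1sc2cccc(C)c2c1Nc1cc(OC)c(OC)c(OC)c1`): 6250 nM
Compound 3 (`COC(=O)c1sc2ccccc2c1Nc1cc(OC)c(OC)c(OC)c1`): 2850 nM

Compound 3 has the lowest number of the three, and its gaps to both others lie beyond the scatter. Compound 4 (`COC(=O)c1sc2cccc(C)c2c1Nc1cc(OC)c(OC)c(OC)c1`) differs from it by one change, methyl in place of hydrogen on an aromatic carbon. The same swap appears in a 1.4-fold lower number from compound 1 to compound 2 (0.14 log units; within the scatter), a step within the scatter. The change in a 3.0-fold lower number from compound 1 to compound 3 (0.48 log units; beyond the scatter) also separates compound 2 from compound 4, and it points to a number not far from that of compound 3. Only a small drop in this assay is therefore expected, perhaps none beyond the scatter. The estimate is a 1.4-fold lower number from compound 3 to compound 4 (0.13 log units; within the scatter) as the expected step. Compound 4 is expected at about 2100 nM, with an estimated range from 1000 nM to 4300 nM around it.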

Compound 4, half-maximal inhibitory concentration: 4580 nM
Beside the measured number, compound 4's estimate is 2.2-fold (0.34 log units) below it; measured number outside the range, above it.
By their numbers in this assay, from the lowest: compounds 3, 4, 2 and 1 (each within the scatter of the next, the first and the last beyond it).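

In this assay, methyl in place of hydrogen on this aromatic carbon gives a 1.6-fold higher number from compound 3 to compound 4 (0.21 log units; within the scatter), so the change stays within the scatter on a second core, and the two steps agree: the same change on two cores in this assay, a 1.4-fold lower number (0.14 log units; within the scatter) from compound 1 to compound 2 and a 1.6-fold higher number (0.21 log units; within the scatter) from compound 3 to compound 4, 2.2-fold (0.34 log units) apart, within the scatter of two such steps. The ester change, hydrogen in place of methyl on the chain carbon, gives only a 1.4-fold lower number from compound 2 to compound 4 (0.14 log units; within the scatter) once the ring methyl is present, yet this cannot be told apart from its earlier, larger step: the same change on two cores in this assay, a 3.0-fold lower number (0.48 log units; beyond the scatter) from compound 1 to compound 3 and a 1.4-fold lower number (0.14 log units; within the scatter) from compound 2 to compound 4, 2.2-fold (0.34 log units) apart, within the scatter of two such steps.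

The compounds shown leave open whether an amine or a longer chain on this aromatic carbon would shift the number beyond the scatter.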